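Compound 2 to compound 4: ethyl on the shared core

The source may report more compounds than this note shows. Statements on the series, on what has been measured and on what is new or still open speak of the compounds shown alone.

In an ADME assay on MT4 cells (Homo sapiens) for activation, read by MTT assay (a higher number here means that more compound is tolerated, a lower number that less compound is tolerated), compound 1 `CC(C)Sc1nc(Cc2c(F)cccc2Cl)cc(=O)[nH]1` gives > 80000 nM, which is a limit. Compound 2 `CC(C)Sc1nc(C(C)c2c(F)cccc2Cl)cc(=O)[nH]1` gives > 75000 nM, also a limit. Compound 3 `CCCCSc1nc(C(C)c2c(F)cccc2Cl)cc(=O)[nH]1` gives > 73000 nM, again a limit. Compound 2 therefore has no exact value, and neither do its two neighbours.

Compound 4 `CCc1c(C(C)c2c(F)cccc2Cl)nc(SC(C)C)[nH]c1=O` differs from compound 2 by ethyl in place of hydrogen on an aromatic carbon.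

Going by the values given here, two measured steps bear on this only loosely, and neither changes that aromatic carbon: a step that the two limits leave unreadable from compound 1 to compound 2 and a step that the two limits leave unreadable from compound 2 to compound 3. Neither gives a size to carry over. The expected step in this assay is an at least 1.1-fold lower number from compound 2 to compound 4 (0.06 log units; that floor lies within the scatter), estimated to stay within the scatter, with no firm direction. Compound 4 is estimated at 65000 nM, with an expected range of 20000 nM to 120000 nM.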

Compound 4, half-maximal cytotoxic concentration: > 3000 nM
Compound 4 was reported as a limit (the forecaster's own chance of this, stated with the estimate: 65%); the middle value does not contradict the limit.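

Compound 2 stands at > 75000 nM, a limit. Going by these compounds alone, compound 4 stands at > 3000 nM, also a limit, so no step between compound 2 and compound 4 can be read. Going by these compounds, whether ethyl in place of hydrogen on an aromatic carbon changes the half-maximal cytotoxic concentration stays open.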